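Changing the aryl group on the amine of compound 1

The source may hold more compounds than are shown below. What is called first, only, known or untested is meant among the compounds shown, and "the series" means these compounds.

In a functional assay on A549 cells (Homo sapiens) for cytotoxicity, read by sulforhodamine B assay (a lower number here means a stronger inhibitor, a higher number a weaker inhibitor), compound 1 `C=C1[C@@H](OC(C)=O)C[C@@H]2[C@](C)(COC=O)[C@H](OC(C)=O)CC[C@@]2(C)[C@@H]1C[C@@H](Nc1ccccc1F)C1=CCOC1=O` gives 23600 nM and compound 2 `C=C1[C@@H](OC(C)=O)C[C@@H]2[C@](C)(COC=O)[C@H](OC(C)=O)CC[C@@]2(C)[C@@H]1C/C=C1/C(=O)OC[C@H]1OC(C)=O` gives 19000 nM within the scatter of each other. Among the measured compounds shown here, these two form the high end of the numbers so far, while compound 3 `C=C1[C@@H](OC(C)=O)C[C@@H]2[C@](C)(CO[Si](C)(C)C(C)(C)C)[C@H](OC(C)=O)CC[C@@]2(C)[C@@H]1C[C@@H](Nc1ccccc1F)C1=CCOC1=O` reads lower at 3190 nM in a clear drop. Compound 4 `C=C1[C@@H](OC(C)=O)C[C@@H]2[C@](C)(COC=O)[C@H](OC(C)=O)CC[C@@]2(C)[C@@H]1C[C@@H](Nc1ccc(C(=O)O)cc1)C1=CCOC1=O` carries one change from compound 1, with 4-carboxyphenyl in place of 2-fluorophenyl on an amine nitrogen is the full count. For the measured compounds named here, the one measured step of a 7.4-fold lower number from compound 1 to compound 3 (0.87 log units; beyond the scatter) is modest but sits elsewhere, on an oxygen on a saturated carbon, so it says little here. Going by the values given here, no measured step touches this amine nitrogen, so no shift beyond the scatter is expected in this assay for now. The estimated step of a 1.0-fold higher number from compound 1 to compound 4 (0.01 log units; within the scatter) is expected to stay small. Compound 4 is expected at 24000 nM with 9000 nM to 60000 nM as its estimated range.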

Compound 4, half-maximal inhibitory concentration: > 50000 nM
Compound 4: only a limit was reported; the forecaster's own chance of this, stated with the estimate: 15%; middle value at least 2.0-fold (0.31 log units) away from the limit.
By their numbers in this assay, from the lowest: compound 3; then compounds 2 and 1 (each within the scatter of the next). At a limit, above all of these: compound 4.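

Among the compounds shown here, replacing 2-fluorophenyl with 4-carboxyphenyl on the amine nitrogen brings an at least 2.1-fold higher number from compound 1 to compound 4 (0.32 log units; beyond the scatter) in this assay and shows for the first time that the aryl group at this position can change the reading, here towards weaker action on the cells. As far as these compounds go, compound 4 reads > 50000 nM as a limit of the assay and not a number, so the full size of this step stays unknown.

The swap changes both the group and where it stands, so these compounds cannot say which of the two matters. From the compounds shown here alone, how a 4-fluorophenyl, a plain phenyl or a methyl ester in place of the carboxylic acid would read remains open.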